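Swapping benzyl for tert-butyl on the shared core

The source may hold more compounds than are shown below. What is called first, only, known or untested is meant among the compounds shown, and "the series" means these compounds.

The compounds share one core and differ in the group on an aromatic carbon of the fused ring system. In an assay on membranes from HEK293 cells for displacement of a labelled ligand from Type-2 angiotensin II receptor (Homo sapiens), read by radioligand binding (on this read-out higher numbers stand for weaker inhibition and lower numbers for stronger inhibition), compound 1 `CCCCOC(=O)NS(=O)(=O)c1ccc(CCC)cc1-c1ccc(Cn2c(C3CCCCC3)nc3ccccc32)cc1` gives 130 nM, and compound 3 `CCCCOC(=O)NS(=O)(=O)c1ccc(CCC)cc1-c1ccc(Cn2c(Cc3ccccc3)nc3ccccc32)cc1` gives 15 nM; the change from compound 1 to compound 3 brought an 8.7-fold lower number from compound 1 to compound 3 (0.94 log units; beyond the scatter). Compound 2 `CCCc1ccc(S(=O)(=O)NC(=O)OCCCC(F)(F)F)c(-c2ccc(Cn3c(C(C)(C)C)nc4ccccc43)cc2)c1`, which carries tert-butyl but a different carbamate chain, gives 4.5 nM in this assay, so compound 3 sits second highest of the three numbers. Compound 4 `CCCCOC(=O)NS(=O)(=O)c1ccc(CCC)cc1-c1ccc(Cn2c(C(C)(C)C)nc3ccccc32)cc1` differs from compound 3 by tert-butyl in place of benzyl on an aromatic carbon. Among the compounds with values here, no measured step isolates this exact change; the only bearing step is the one from compound 1 to compound 3, which showed that the group here matters. Compound 4 is expected to land at 7 nM in this assay, between 2 nM and 25 nM, which would mean an estimated 2.1-fold lower number from compound 3 to compound 4 (0.33 log units; beyond the scatter).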

Compound 4, inhibition constant: 5.3 nM
The estimate for compound 4 lay 1.3-fold (0.12 log units) above the measured number; the measured number falls inside the stated range.
By their numbers in this assay, from the lowest: compounds 2 and 4 (each within the scatter of the next); then compound 3; then compound 1.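

Tert-butyl in place of benzyl gives a 2.8-fold lower number from compound 3 to compound 4 (0.45 log units; beyond the scatter) and tert-butyl in place of cyclohexyl gives a 25-fold lower number from compound 1 to compound 4 (1.39 log units; beyond the scatter), so of these three groups on this aromatic carbon, the one without a ring gives the lowest number. With tert-butyl on the core, methyl in place of trifluoromethyl on the carbamate chain gives a 1.2-fold higher number from compound 2 to compound 4 (0.07 log units; within the scatter), so that chain change does not move the number beyond the scatter. Nothing available explains these differences. Going by these compounds, whether isopropyl or an amine at this carbon would match tert-butyl remains open, as does whether the trifluoromethyl chain would read the same alongside benzyl.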